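A few compounds are considered here, and "the series" means these few. Any claim that something is new, unique, unknown or untested is made for them only; others in the source may bear on it.

Three compounds that share one core, two aromatic systems joined through two amine linkers to a central six-membered ring, have been tested in a functional assay on MDA-MB-231 cells (Homo sapiens) for antiproliferative activity, read by MTT assay, with a stated time of 48 h; a higher number here means a weaker inhibitor, a lower number a stronger inhibitor. Compound 1, with the structure `Cc1ccc2nc(Nc3nc(Nc4ccc(S(N)(=O)=O)cc4)ncc3C)sc2c1`, gives in this assay 9080 nM. Compound 2, with the structure `CS(=O)(=O)c1ccc(Nc2nccc(Nc3nc4ccc(F)cc4s3)n2)cc1`, gives in this assay 2080 nM. Compound 3, with the structure `Cc1cnc(Nc2ccc(S(N)(=O)=O)cc2)nc1Nc1nc2ccccc2s1`, gives in this assay 16800 nM. Compound 2 has the lowest number, and its steps to compound 1 and to compound 3 both lie beyond the usual scatter, so compound 2 is the strongest inhibitor of the three.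

Compound 3 and compound 1 differ in one place: methyl in place of hydrogen on an aromatic carbon. This change produced a 1.9-fold lower number from compound 3 to compound 1 (0.27 log units; within the scatter), which means it left the result essentially unmoved.

Compound 4, with the structure `Cc1cnc(Nc2ccc(S(C)(=O)=O)cc2)nc1Nc1nc2ccc(F)cc2s1`, is still unmeasured. It is related to compound 2 by the same kind of change: methyl in place of hydrogen on an aromatic carbon. The surroundings are not the same as in compound 1, where the methyl sits on a six-membered aromatic ring of carbon only, part of a fused or bridged system of two rings, meta to a fused ring and para to a fused ring; in compound 4 it sits on a six-membered aromatic ring with 2 nitrogen, ortho to a large group, two atoms from the ring nitrogen, para to a large group. How the core of compound 2 differs from the core of compound 3 is not broken down here.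

Going by the values given here, for compound 4 the expected step is a 1.4-fold lower number from compound 2 to compound 4 (0.14 log units; within the scatter), because a 1.9-fold lower number from compound 3 to compound 1 (0.27 log units; within the scatter) is the only comparable change measured here and it stayed within the scatter. Compound 4 is therefore estimated to give about 1500 nM in this assay, with a likely range from 500 nM to 5000 nM.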

Compound 4, half-maximal inhibitory concentration: > 50000 nM
Compound 4 was reported as a limit; the forecaster's own chance of this, stated with the estimate: 3%; middle value at least 33-fold (1.52 log units) from the limit.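

In this assay, methyl in place of hydrogen on an aromatic carbon gave an at least 24-fold higher number from compound 2 to compound 4 (1.38 log units; beyond the scatter), so the small step seen on one core did not carry over to the other, and the same change cannot be assumed to act alike across this series: the same change on two cores in this assay, a 1.9-fold lower number (0.27 log units; within the scatter) from compound 3 to compound 1 and an at least 24-fold higher number (1.38 log units; beyond the scatter) from compound 2 to compound 4, at least 44-fold (1.64 log units) apart, beyond the scatter of two such steps

As far as these compounds go, compound 4 gives > 50000 nM, which is a limit of the assay and not a number, so its true value remains unknown.

What the comparison does not show is the reason for the gap: the methyl sits on a six-membered aromatic ring of carbon only in compound 1 and on a six-membered aromatic ring with 2 nitrogen in compound 4, the rest of the two cores differs as well, and a single pair on each side cannot separate these differences.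

Going by these compounds alone, it remains open whether taking away the methyl on the ring with 2 nitrogen from compound 1 or compound 3 would give a step as large as the one seen for compound 2 and compound 4. From the compounds shown here alone, it is also open whether an ethyl or a methoxy group at that place would give a result like that of the methyl.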